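This account rests on a few compounds, and the source may have more. Where it says the series, first, only, none or still open, it means among the compounds named here.

Working notes on an ADME assay on liver for metabolic stability, with Liver microsome (Homo sapiens) as the target, using microsomes; a higher number here means faster removal of the compound, a lower number slower removal. Compound 3 (`O=C(Nc1cc(-c2ccccn2)n[nH]1)N1CCC(c2ccc(Cl)cc2)CC1`) gives 30 mL.min-1.g-1. Compound 1 (`N#Cc1ccc(C2CCN(C(=O)Nc3cc(-c4ccccn4)n[nH]3)CC2)cc1`) gives 25.3 mL.min-1.g-1, which lies within the scatter of compound 3. Compound 2 (`N#Cc1ccc(OC2CCN(C(=O)Nc3cc(-c4ccccn4)n[nH]3)CC2)cc1`) gives 14.7 mL.min-1.g-1, and the gap to it is modest: a 2.0-fold higher number from compound 2 to compound 3 (0.31 log units; beyond the scatter).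

The next structure is compound 4 (`O=C(Nc1cc(-c2ccccn2)n[nH]1)N1CCC(c2ccccc2)CC1`). The change is hydrogen in place of chloro on an aromatic carbon, para to a large group, or 4-chlorophenyl to phenyl.

Within the data shown here, no measured pair carries this exact change. The closest evidence is a 1.2-fold higher number from compound 1 to compound 3 (0.07 log units; within the scatter), with chloro in place of cyano on an aromatic carbon. This shows a swap of that substituent moving the number very little. The step of a 2.0-fold higher number from compound 2 to compound 3 (0.31 log units; beyond the scatter) also replaces the 4-cyanophenoxy group as a whole, so it bears less directly, and a 1.7-fold lower number from compound 1 to compound 2 (0.24 log units; within the scatter) leaves the aromatic substituent untouched. With only these three compounds, the direction is poorly supported.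

The expected step in this assay is a 1.2-fold lower number from compound 3 to compound 4 (0.08 log units; within the scatter), which is estimated to stay within the scatter, with a slightly lower number only tentatively favoured. For compound 4 the estimated value is 25 mL.min-1.g-1, with an expected range from 14 mL.min-1.g-1 to 42 mL.min-1.g-1.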

Compound 4, intrinsic clearance in microsomes: 15.3 mL.min-1.g-1
Estimate against measurement, compound 4: 1.6-fold (0.21 log units) above; the measured number falls inside the stated range.
By their numbers in this assay, from the lowest: compounds 2, 4, 1 and 3 (each within the scatter of the next, the first and the last beyond it).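

In this assay, compound 4 gives the series its first reference with hydrogen on an aromatic carbon, para to a large group, and neither a 2.0-fold lower number from compound 3 to compound 4 (0.29 log units; within the scatter) nor a 1.7-fold lower number from compound 1 to compound 4 (0.22 log units; within the scatter) leaves the scatter, so hydrogen, chloro and cyano in this place are not separated, although the step from chloro to hydrogen lies close to its edge. At the saturated ring carbon, a 1.0-fold higher number from compound 2 to compound 4 (0.02 log units; within the scatter) puts phenyl and 4-cyanophenoxy within the scatter of each other, and with compound 4 within the scatter of both compound 2 and compound 3, the series now forms a continuous run of numbers in which only the two ends are separated. No measured property of these groups is available to account for any of these steps.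

From the compounds shown here alone, whether an amine or a methoxy group in this same place would give a step beyond the scatter remains open. Going by these compounds, it is also open whether hydrogen in place of cyano would give a similar step on the 4-cyanophenoxy group of compound 2.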